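A few compounds are considered here, and "the series" means these few. Any claim that something is new, unique, unknown or untested is made for them only; others in the source may bear on it.

- Compound 1 `Cn1c(=O)c(=O)n(C2CCCC2)c2nc(N/N=C/c3ccccc3)ncc21`: > 100000 nM (a limit)
- Compound 2 `Cc1cccc(/C=N/Nc2ncc3c(n2)n(C2CCCC2)c(=O)c(=O)n3C)c1`: > 100000 nM (a limit)
- Compound 3 `Cn1c(=O)c(=O)n(C2CCCC2)c2nc(N/N=C/c3ccc(Cl)cc3)ncc21`: 9810 nM

In a functional assay on HCT-116 cells (Homo sapiens) for antiproliferative activity, read by MTT assay (on this read-out higher numbers stand for weaker inhibition and lower numbers for stronger inhibition), compound 1 gives only a limit, > 100000 nM, which is the limit of > 100000 nM in this assay, at which 2 of the 3 values shown sit. Compound 4 `Cn1c(=O)c(=O)n(C2CCCC2)c2nc(N/N=C/c3ccc(F)c(Cl)c3)ncc21` departs from it as follows: 3-chloro-4-fluorophenyl in place of phenyl on a carbon with a double bond to nitrogen. The methyl change gives a step that the two limits leave unreadable from compound 1 to compound 2, so it offers no guide. The nearest guide is an at least 10-fold lower number from compound 1 to compound 3 (1.00 log units; beyond the scatter), for chloro in place of hydrogen on an aromatic carbon. A further step, an at least 10-fold lower number from compound 2 to compound 3 (1.00 log units; beyond the scatter), also ends at the same compound. Compound 4 also carries a chloro, though as 3-chloro-4-fluorophenyl rather than 4-chlorophenyl, so a lowering of at least modest size is expected in this assay. The expected change is an at least 11-fold lower number from compound 1 to compound 4 (1.04 log units; beyond the scatter). Compound 4 is estimated at 9000 nM, with an expected range of 2500 nM to 40000 nM.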

Compound 4, half-maximal inhibitory concentration: 9020 nM
Compound 4: middle estimate off by 1.0-fold (0.00 log units), on the low side; low and high end bracket the measured number.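

In this assay, 3-chloro-4-fluorophenyl on this carbon gives an at least 11-fold lower number from compound 1 to compound 4 (1.04 log units; beyond the scatter) and an at least 11-fold lower number from compound 2 to compound 4 (1.04 log units; beyond the scatter), so both rings carrying chloro now give numbers. Against 4-chlorophenyl it gives a 1.1-fold lower number from compound 3 to compound 4 (0.04 log units; within the scatter), so the two rings cannot be told apart here. Compound 1 and compound 2 each give only a limit, so the two larger steps have open sizes: the limit of > 100000 nM in this assay, at which 2 of the 4 values shown sit.

On these data alone, whether fluoro alone on the phenyl would serve as chloro does stays open. So does how an amine or a carboxylic acid on that ring would read.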